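A few compounds are considered here, and "the series" means these few. Any claim that something is new, unique, unknown or untested is made for them only; others in the source may bear on it.

Compound 2 `O=C(NCCSc1nonc1/C(=N/O)Nc1ccc(F)c(C(F)F)c1)C1CS(=O)(=O)C1` holds the lower of the two numbers measured in an assay for inhibition of Indoleamine 2,3-dioxygenase 1 (Homo sapiens), read by fluorescence, with a stated time of 1 h (a higher number here means a weaker inhibitor, a lower number a stronger inhibitor), where compound 2 gives 70 nM. Going by the values given here, its only measured neighbour is compound 1 `CC1(C(=O)NCCSc2nonc2/C(=N/O)Nc2ccc(F)c(C(F)F)c2)CCN1`, which in this assay gives 360 nM; the single step between them, a 5.1-fold lower number from compound 1 to compound 2 (0.71 log units; beyond the scatter), came from exchanging the group on the carbonyl carbon. Compound 3 `CC(C)(O)CC(=O)NCCSc1nonc1/C(=N/O)Nc1ccc(F)c(C(F)F)c1` alters that same carbonyl carbon once more: a group of 5 heavy atoms (4 carbon, 1 oxygen; no ring) in place of a group of 6 heavy atoms (3 carbon, 2 oxygen, 1 sulfur; one four-membered non-aromatic ring with 1 hetero atom), on a carbonyl carbon. Among the compounds with values here, the only measured step that bears on this is the one from compound 1 to compound 2, and it shows that changing the group at this carbonyl can move the number by a modest amount. That step concerned a quite different exchange, though, and here the entering group has no ring, so it offers only a loose guide. With compound 2 already the lowest number shown, one expects for compound 3 in this assay a small rise rather than a further fall, of the order a 2.1-fold higher number from compound 2 to compound 3 (0.33 log units; beyond the scatter), which may well lie within the scatter. Compound 3 is estimated at 150 nM, with a range from 50 nM to 500 nM.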

Compound 3, half-maximal inhibitory concentration: 140 nM
For compound 3 the middle estimate is 1.1-fold (0.03 log units) above the measured one, and the stated range covers the measured number.
By their numbers in this assay, from the lowest: compounds 2 and 3 (each within the scatter of the next); then compound 1.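

In this assay, the step of a 2.0-fold higher number from compound 2 to compound 3 (0.30 log units; within the scatter) shows that the entering 2-hydroxy-2-methylpropyl group, which has no ring, cannot be told apart from the four-membered ring group of compound 2 on this carbonyl carbon, so among these compounds the ring is not needed to reach this range. The step of a 2.6-fold lower number from compound 1 to compound 3 (0.41 log units; beyond the scatter) shows that the open chain also keeps a gap beyond the scatter from compound 1, which leaves compound 1, the only one of the three with a nitrogen in this group, standing apart from two otherwise quite different groups that each carry oxygen. No measurement presented here explains this behaviour at the carbonyl carbon.

The compounds shown leave open whether it is the ring nitrogen of compound 1 or some other feature of its group that sets it apart, which an open-chain amine on the same carbonyl carbon could help to separate. They also leave open how a carboxylic acid, a longer chain or 2-methylpropyl without the hydroxy group would compare with the 2-hydroxy-2-methylpropyl group here.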